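A Methoxy Substituent Tested on an Inactive Scaffold

A few compounds are considered here, and "the series" means these few. Any claim that something is new, unique, unknown or untested is made for them only; others in the source may bear on it.

In a functional assay on MCF7 cells (Homo sapiens) for cytotoxicity, read by sulforhodamine B assay, with a stated time of 48 h (on this read-out lower numbers stand for higher toxicity in this test and higher numbers for lower toxicity in this test), compound 2 `COc1ccc(/C(Cl)=C/C=C(\C#N)C(=O)c2c[nH]c3ccccc23)cc1` gives only a limit, > 100000 nM. Compound 1 `COc1ccc(/C(Cl)=C/C=C(\C#N)C(=O)c2c[nH]c3ccc(Br)cc23)cc1` likewise yields only a limit in this assay, > 100000 nM. The step that the two limits leave unreadable from compound 1 to compound 2 therefore cannot be sized, and the limit of > 100000 nM in this assay, at which 2 of the 2 values shown sit, is the whole of what the measurements show for these two compounds. Compound 3 `COc1ccc(/C(Cl)=C/C=C(\C#N)C(=O)c2c[nH]c3ccc(OC)cc23)cc1` differs from compound 2 by methoxy in place of hydrogen on an aromatic carbon. For the measured compounds named here, the single measured step, from compound 1 to compound 2, concerns a different substituent and is itself unreadable, so it gives no guide to the size or direction of the change now considered. Since compound 2 sits at the limit of this assay, no departure from that limit is expected in this assay for compound 3, and the step that the limit leaves unreadable from compound 2 to compound 3 is expected to be nominal. Compound 3 is thus estimated at 150000 nM, within the range 50000 nM to 500000 nM.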

Compound 3, concentration lethal to 50% of the cells: > 100000 nM
Compound 3: only a limit was reported; the forecaster's own chance of this, stated with the estimate: 80%; the middle value lies beyond the limit too.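

Compound 3, like compound 1 and compound 2, gives only a limit, so no step among these three compounds can be read: the limit of > 100000 nM in this assay, at which 3 of the 3 values shown sit. The compounds shown leave open whether bromo, hydrogen and methoxy on this aromatic carbon differ at all in this assay.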